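The compounds below may be only part of what the source reports. "The series", "measured", "known", "first", "only" and "open" are said of these compounds alone.

Values measured in a functional assay on MCF7 cells (Homo sapiens) for antiproliferative activity, read by MTT assay, with a stated time of 48 h; a higher number here means a weaker inhibitor, a lower number a stronger inhibitor:
- compound 1 `COc1ccc(C(=O)c2ccc(OC)c3c2C=CC(C)(C)O3)c(NC(=O)CN)c1`: 1250 nM
- compound 2 `COc1ccc(C(=O)c2ccc(OC)c3c2OC(C)(C)C=C3)c(NC(=O)CN(C)C)c1`: 2680 nM
- compound 3 `COc1ccc(C(=O)c2cc(OC)c(OC)c(OC)c2)c(NC(=O)CO)c1`: 230 nM

Compound 3 has the lowest number of the three, so it is the strongest inhibitor here, and both other compounds lie above it by more than the usual scatter.

Compound 4 `CCNCC(=O)Nc1cc(OC)ccc1C(=O)c1cc(OC)c(OC)c(OC)c1` keeps the core of compound 3 but has ethylamino in place of hydroxy on a saturated chain carbon bound to a carbonyl carbon. Among the compounds with values here, no measured pair shows this change alone. The nearest hints are the two compounds with a nitrogen-bearing chain, compound 1 at 1250 nM and compound 2 at 2680 nM, yet their cores also differ from that of compound 3, so they guide the direction only loosely. A moderate loss of strength, meaning a higher number in this assay, is therefore expected, and the expected step is a 2.4-fold higher number from compound 3 to compound 4 (0.38 log units; beyond the scatter). For compound 4 the estimated value is 550 nM, with an expected range of 130 nM to 2300 nM.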

Compound 4, half-maximal inhibitory concentration: 1050 nM
For compound 4 the middle estimate is 1.9-fold (0.28 log units) below the measured one, and the stated range covers the measured number.
By their numbers in this assay, from the lowest: compound 3; then compounds 4 and 1 (each within the scatter of the next); then compound 2.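

A single change at this position now has a reading of its own: with the core of compound 3 kept, ethylamino in place of hydroxy on a saturated chain carbon bound to a carbonyl carbon gives in this assay a 4.6-fold higher number from compound 3 to compound 4 (0.66 log units; beyond the scatter). The earlier compounds shown here with a nitrogen-bearing chain also differed from compound 3 in their cores, so they could not show that this chain change alone weakens the inhibitor, and this pair does show it. No measurement at hand accounts for the loss.

The compounds shown leave open whether the loss follows the nitrogen or the two added carbons. Going by these compounds, how a carboxylic acid or a longer chain such as butylamino would read at this place on the same core also remains open.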